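Mirror Image of Compound 3: Expectation from an Enantiomer Pair

A few compounds are considered here, and "the series" means these few. Any claim that something is new, unique, unknown or untested is made for them only; others in the source may bear on it.

Measured so far in an ADME assay on the whole organism with Oryza sativa as the target, tested at 10 uM; a higher number here means a weaker effect of the compound at the concentration tested, a lower number a stronger effect:
compound 1, `Cc1ccccc1NC(=O)N[C@H](C)c1ccccc1`, gives 99%
compound 2, `Cc1ccccc1NC(=O)N[C@@H](C)c1ccccc1`, gives 99%
compound 3, `Cc1ccc(NC(=O)N[C@H](C)c2ccccc2)cc1`, gives 64%

Compound 3 stands lowest of the three numbers in this assay. Its nearest neighbour is compound 1, whose number lies beyond the scatter above it, and compound 2 lies equally far above it, so compound 3 is the strongest of the measured compounds at the concentration tested.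

The unmeasured compound 4, `Cc1ccc(NC(=O)N[C@@H](C)c2ccccc2)cc1`, differs from compound 3 as follows: the two compounds have the same atoms and bonds and differ only in configuration as drawn: 1 of 1 stereo elements differ; a stereocentre at a saturated chain carbon is drawn R in compound 3 and S in compound 4.

Within the data shown here, one measured step bears directly on this change. Among the measured compounds shown here, compounds 1 and 2 form the same kind of pair, and that step gave no change at the digits printed from compound 1 to compound 2 (within the scatter); the only ground for reading it is the fact that compounds 1 and 2 differ only in the configuration as drawn. The account therefore expects no step beyond the scatter in this assay for compound 4, in neither direction. Compound 4 is expected to give 64%, with a range from 50% to 78%. The expected step is no change at the digits printed from compound 3 to compound 4 (within the scatter), which is no change beyond the scatter.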

Compound 4, a percentage reported as activity, at one concentration (the size of the read-out at that concentration, not a potency): 100%
Compound 4: middle estimate off by 36 percentage points, on the low side, and the stated range ends below it.
By their numbers in this assay, from the lowest: compound 3; then compounds 1, 2 and 4 (each within the scatter of the next).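

In this assay, the inversion of the stereocentre at the saturated chain carbon from R to S gives a number 36 percentage points higher from compound 3 to compound 4 (beyond the scatter), so configuration at this position can matter in this series. The same inversion gave no change at the digits printed from compound 1 to compound 2 (within the scatter), which means that the change does not carry one fixed size across the two pairs and that its outcome depends on the rest of the structure. The step within the second pair can be laid to configuration alone, because nothing else separates the two structures: the fact that compounds 3 and 4 differ only in the configuration as drawn

The compounds shown do not tell why the R form stands apart from the S form in one pair and not in the other, and with only two such pairs no general rule for this stereocentre can be drawn from them. They also leave open whether a gap of this kind between the two forms would persist if a longer chain or a carboxylic acid took the place of the methyl group on the stereocentre.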